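Bromo substitution and cytotoxicity limits in the series

A few compounds are considered here, and "the series" means these few. Any claim that something is new, unique, unknown or untested is made for them only; others in the source may bear on it.

Compound 1 `Cc1cc(Oc2ccc3cc(C#N)ccc3c2)nc(Nc2ccc(C#N)cc2)n1` carries a methyl on the core; compound 3 `N#Cc1ccc(Nc2nccc(Oc3ccc4cc(C#N)ccc4c3)n2)cc1` differs from it by hydrogen in place of methyl on an aromatic carbon. In an ADME assay on MT4 cells (Homo sapiens) for cytotoxicity, read by MTT assay, with a stated time of 4 days (on this read-out lower numbers stand for higher toxicity in this test and higher numbers for lower toxicity in this test), compound 1 reaches only the assay limit, > 331000 nM, not a number. Compound 2 `Cc1cc(Oc2ccc3cc(C#N)ccc3c2Br)nc(Nc2ccc(C#N)cc2)n1` arises from compound 1 through (bromo in place of hydrogen on an aromatic carbon). In this assay compound 2 also gives only a limit, > 274000 nM. The step that the two limits leave unreadable from compound 1 to compound 2 therefore cannot be sized, as the limit of > 274000 nM in this assay, at which 1 of the 3 values shown sits, and the limit of > 331000 nM in this assay, at which 1 of the 3 values shown sits, show. In this assay compound 3 stands at a limit too, > 68800 nM. Hence a step that the two limits leave unreadable from compound 1 to compound 3 is unreadable as well; see (the limit of > 68800 nM in this assay, at which 1 of the 3 values shown sits). Compound 4 `N#Cc1ccc(Nc2nccc(Oc3cc4ccc(C#N)cc4cc3Br)n2)cc1` is not yet measured. It arises from compound 3 by bromo in place of hydrogen on an aromatic carbon, the same kind of change as that from compound 1 to compound 2, though the place differs: in compound 2 the bromo sits ortho to a fused ring, in compound 4 para to a fused ring. The expected step is a step that the limit leaves unreadable from compound 3 to compound 4, resting on the unreadable a step that the two limits leave unreadable from compound 1 to compound 2, where both partners sit at limits. Compound 4 is thus expected at 100000 nM, between 40000 nM and 300000 nM, most likely reported again only as a limit.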

Compound 4, half-maximal cytotoxic concentration: > 56500 nM
Compound 4: a limit, no number; the forecaster's own chance of this, stated with the estimate: 75%; the middle value does not contradict the limit.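

In this assay compound 4 gives only a limit, > 56500 nM, not a number. Compound 3 likewise gives only a limit, > 68800 nM, and no step can be read between compound 3 and compound 4. The compounds shown leave open whether bromo in place of hydrogen shifts the half-maximal cytotoxic concentration at all.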